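This account rests on a few compounds, and the source may have more. Where it says the series, first, only, none or still open, it means among the compounds named here.

Measured compounds:
- Compound 1 `Cc1cccc(-c2noc(C3CN(S(=O)(=O)c4cccc(C)c4)C3)n2)c1` gives 650 nM in an assay on HEK293 cells for negative allosteric modulation of metabotropic glutamate receptor 5 (Homo sapiens), read by FLIPR; a higher number here means a weaker inhibitor, a lower number a stronger inhibitor.
- Compound 2 `Cc1cccc(S(=O)(=O)N2CC(c3nc(-c4cccc(Cl)c4)no3)C2)c1` gives 390 nM in this assay.
- Compound 3 `O=C(N1CCCCCC1)N1CC(c2nc(-c3cccc(Cl)c3)no2)C1` reaches only the limit > 10000 nM in this assay, which is a limit of the assay and not a number.

Of the two numbers, compound 1 has the higher one, and its nearest neighbour is compound 2, with a 1.7-fold lower number from compound 1 to compound 2 (0.22 log units; within the scatter). The value for compound 3 is a limit of > 10000 nM in this assay, at which 1 of the 3 values shown sits, and gives no number to compare.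

Compound 4 `Cc1cccc(-c2noc(C3CN(S(=O)(=O)c4ccc(Cl)cc4)C3)n2)c1` differs from compound 1 by 4-chlorophenyl in place of 3-methylphenyl on a sulfonyl sulfur. Among the measured compounds shown here, only one measured step speaks to a chloro entering where a methyl left: that of a 1.7-fold lower number from compound 1 to compound 2 (0.22 log units; within the scatter), which stayed within the scatter. For the measured compounds named here, in compound 4 the exchange concerns the aryl group on the sulfonyl sulfur and also changes the pattern of that ring, for which no measured pair exists. The expectation in this assay is therefore a step no larger than the scatter, with at most a slight lean towards a lower number as seen for compound 2.

Compound 4 is estimated at 500 nM, with a range from 200 nM to 1500 nM, which means an expected step of a 1.3-fold lower number from compound 1 to compound 4 (0.11 log units; within the scatter).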

Compound 4, half-maximal inhibitory concentration: 1100 nM
Compound 4: middle estimate off by 2.2-fold (0.34 log units), on the low side, within the range that was stated.
By their numbers in this assay, from the lowest: compounds 2, 1 and 4 (each within the scatter of the next, the first and the last beyond it). At a limit, above all of these: compound 3.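

Putting 4-chlorophenyl in place of 3-methylphenyl on the sulfonyl sulfur gives a 1.7-fold higher number from compound 1 to compound 4 (0.23 log units; within the scatter) in this assay. Among the compounds shown here, the only earlier step between measured compounds left the 3-methylphenyl on the sulfonyl sulfur untouched, so this is the first reading of a change to that aryl group, and it shows that this exchange stays within the scatter of the assay. The result therefore sets 4-chlorophenyl and 3-methylphenyl at this place level with each other, and nothing available here bears on why the step has this size.

As far as these compounds go, what stays open is whether the chloro and the changed ring pattern each have an effect of their own that is hidden in this single exchange, since the two arrive together and a 4-methylphenyl or an unsubstituted phenyl on the sulfonyl sulfur would be needed to pull them apart. Also open, from the compounds shown here alone, is how far this place tolerates larger departures from these two aryl groups, such as a phenyl ring carrying a carboxylic acid or an amine, or a simple alkyl chain on the sulfonyl sulfur.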